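Chain extension in the anilide series: compound 2 to compound 3

The source may hold more compounds than are shown below. What is called first, only, known or untested is meant among the compounds shown, and "the series" means these compounds.

Of the compounds shown here, two have been measured. Compound 1 `CCCCCCCc1nc(N)n(CC(=O)Nc2ccccc2)c1-c1ccccc1Br` and compound 2 `CCCCCCc1nc(N)n(CC(=O)Nc2ccc(C)cc2)c1-c1ccccc1Br` share the core and differ both in the anilide portion and in the length of the alkyl chain. In a functional assay on A-375 cells (Homo sapiens) for antiproliferative activity, read by MTT assay, with a stated time of 48 h (a lower number here means a stronger inhibitor, a higher number a weaker inhibitor), compound 1 gives 9200 nM. In this assay compound 2 gives 5100 nM. The two values lie within the usual scatter of each other, so the data so far say nothing about either of the two differences between them, and neither compound can be set apart from the other.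

Compound 3 `CCCCCCCc1nc(N)n(CC(=O)Nc2ccc(C)cc2)c1-c1ccccc1Br` keeps the anilide portion of compound 2 and differs from it by methyl in place of hydrogen on a saturated chain carbon, six bonds along the chain from an aromatic carbon, so that the chain is longer by one carbon. For the measured compounds named here, no step of this kind has been measured; the only comparison available, compound 1 against compound 2, carries a second difference and is itself within the scatter. The expectation for this assay is therefore a step no larger than the scatter, in no preferred direction. On that basis compound 3 is estimated at 5000 nM, with an expected range from 2500 nM to 10000 nM. The step that this estimate implies is a 1.0-fold lower number from compound 2 to compound 3 (0.01 log units; within the scatter).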

Compound 3, half-maximal inhibitory concentration: 5200 nM
Compound 3: middle estimate off by 1.0-fold (0.02 log units), on the low side, and the stated range covers the measured number.
By their numbers in this assay, from the lowest: compounds 2, 3 and 1 (each within the scatter of the next).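

Compound 3 gives the series its first comparisons that differ in one place, so the two differences that were tangled between compound 1 and compound 2 can now be read apart in this assay: methyl in place of hydrogen on a saturated chain carbon, six bonds along the chain from an aromatic carbon, gives a 1.0-fold higher number from compound 2 to compound 3 (0.01 log units; within the scatter) and methyl in place of hydrogen on an aromatic carbon gives a 1.8-fold lower number from compound 1 to compound 3 (0.25 log units; within the scatter) in the anilide portion. Each step lies within the scatter, so neither this extension of the chain nor this methyl on the anilide portion separates the compounds, and the antiproliferative read-out at these two places tolerates either change within what repeated measurements can resolve. No measurement is at hand that would account for this result.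

Open, on these data alone, is whether a longer chain, or a chain ending in an amine or a carboxylic acid, would give a step beyond the scatter at the saturated chain carbon. Equally open, as far as these compounds go, is whether a group other than methyl on the same aromatic carbon, such as chloro or methoxy, would do so.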